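This account rests on a few compounds, and the source may have more. Where it says the series, first, only, none or still open, it means among the compounds named here.

Measured in an in vitro functional assay on cells for agonist activity at Bombesin receptor subtype-3 (Mus musculus), read by luminescence and calcium flux; a lower number here means that less compound is needed, a higher number that more compound is needed for the effect:
compound 1, `O=C(O)c1ccccc1-c1ccc(CCc2ncc(Cc3cccc(Cl)c3)[nH]2)cc1`: 31 nM
compound 2, `O=C(O)c1ccccc1-c1ccc(CCc2ncc(CC3CCCCCC3)[nH]2)cc1`: 5.7 nM
compound 3, `O=C(O)c1ccccc1-c1ccc(CCc2ncc(Cc3ccccc3Cl)[nH]2)cc1`: 22 nM

Compound 3 stands second highest of the three numbers. Its nearest neighbour is compound 1, the step of a 1.4-fold lower number from compound 1 to compound 3 (0.15 log units; within the scatter) lying within the scatter; the step of a 3.9-fold higher number from compound 2 to compound 3 (0.59 log units; beyond the scatter) is the only one beyond the scatter, and the step of a 5.4-fold lower number from compound 1 to compound 2 (0.74 log units; beyond the scatter) is of similar size. Compound 4, `O=C(O)c1ccccc1-c1ccc(CCc2ncc(Cc3ccccc3)[nH]2)cc1`, differs from compound 3 by hydrogen in place of chloro on an aromatic carbon. For the measured compounds named here, no measured step removes a chloro alone; the measured steps exchange the whole group at that chain carbon, and the one exchange of a chloro position, compound 1 to compound 3, stayed within the scatter. A change no larger than the scatter is therefore expected in this assay. Compound 4 is estimated at 30 nM, between 12 nM and 75 nM, an expected step of a 1.4-fold higher number from compound 3 to compound 4 (0.13 log units; within the scatter).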

Compound 4, half-maximal effective concentration: 11 nM
Compound 4: the middle estimate sits 2.7-fold (0.44 log units) above what was measured, outside the stated range (below it).
By their numbers in this assay, from the lowest: compounds 2, 4, 3 and 1 (each within the scatter of the next, the first and the last beyond it).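

In this assay, the change from chloro to hydrogen is not resolved for the 2-chlorophenyl group, as a 2.0-fold lower number from compound 3 to compound 4 (0.30 log units; within the scatter) stays within the scatter, whereas a 2.8-fold lower number from compound 1 to compound 4 (0.45 log units; beyond the scatter) lies beyond it. Phenyl is also not separated from cycloheptyl at this chain carbon, with a 1.9-fold higher number from compound 2 to compound 4 (0.29 log units; within the scatter) within the scatter, although both chlorophenyl compounds were separated from cycloheptyl.

Open, on these data alone, is how a fluoro or methoxy group on that aromatic carbon, or a longer chain at the chain carbon, would read. No evidence on the cause of these steps is available.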